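The compounds below may be only part of what the source reports. "The series", "measured", "known", "first", "only" and "open" are said of these compounds alone.

Of the compounds shown here, two built on a shared core have so far been measured in a functional assay for inhibition; a lower number here means a stronger inhibitor, a higher number a weaker inhibitor. Compound 1 (`CC(C)(C)c1cc(-c2cc(=O)c3ccc(OCC(=O)N4CCCCC4)cc3o2)cc(C(C)(C)C)c1O`) gives 3000 nM, and compound 2 (`CCCCCCOc1ccc2c(=O)cc(-c3cc(C(C)(C)C)c(O)c(C(C)(C)C)c3)oc2c1`) gives 5000 nM. Among the measured compounds shown here, compound 2 therefore stands level with compound 1, its only neighbour, since the gap between them lies within the usual scatter of repeated measurements.

Compound 3 (`CC(C)(C)c1cc(-c2cc(=O)c3ccc(OCC(O)CO)cc3o2)cc(C(C)(C)C)c1O`) keeps the core and alters one group: 1,2-dihydroxyethyl in place of pentyl on a saturated chain carbon bound to an oxygen on an aromatic ring. In words, 1,2-dihydroxyethyl replaces pentyl on a saturated chain carbon bound to an oxygen on an aromatic ring, which turns hexyloxy into 2,3-dihydroxypropoxy.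

For the measured compounds named here, only one measured step bears on this change, and it involves the same place: a 1.7-fold higher number from compound 1 to compound 2 (0.22 log units; within the scatter). There, replacing (piperidin-1-yl)carbonyl with pentyl moved the number no further than the scatter. Going by the values given here, no measured compound carries a 1,2-dihydroxyethyl group, however, so this single step is only a weak guide and the range must stay wide.

In this assay, no step beyond the scatter is expected, and the estimated step is a 1.3-fold lower number from compound 2 to compound 3 (0.10 log units; within the scatter). The expected value for compound 3 is 4000 nM, with an estimated range from 1500 nM to 12000 nM.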

Compound 3, half-maximal inhibitory concentration: 100 nM
The estimate for compound 3 lay 40-fold (1.60 log units) above the measured number; measured number outside the range, below it.
By their numbers in this assay, from the lowest: compound 3; then compounds 1 and 2 (each within the scatter of the next).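

In this assay, among the compounds shown here, the position on the saturated chain carbon bound to an oxygen on an aromatic ring proves far more sensitive than the earlier compounds suggested. Putting 1,2-dihydroxyethyl in place of pentyl gives a 50-fold lower number from compound 2 to compound 3 (1.70 log units; beyond the scatter) and putting it in place of (piperidin-1-yl)carbonyl gives a 30-fold lower number from compound 1 to compound 3 (1.48 log units; beyond the scatter), whereas swapping those two older groups for each other moved the number no further than the scatter. A flat step between two groups therefore did not show that this position is indifferent to what sits there, and the entering group differs from pentyl in carrying 2 hydrogen-bond donors and 2 hydrogen-bond acceptors, though nothing available here ties the gain to those counts or explains it.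

The compounds shown leave open whether both hydroxyl groups are needed, since a chain with a single hydroxyl, such as 2-hydroxyethoxy, would separate the contribution of one from that of the pair. They also leave open whether an amine or a carboxylic acid on the same short chain would match 2,3-dihydroxypropoxy.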